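A few compounds are considered here, and "the series" means these few. Any claim that something is new, unique, unknown or untested is made for them only; others in the source may bear on it.

In a functional assay on B16-F10 cells (Mus musculus) for cytotoxicity (a lower number here means a stronger inhibitor, a higher number a weaker inhibitor), compound 1 (`O=c1oc2ccccc2c2nc3c(ccc4cc[nH]c43)c(-c3ccc(C(F)(F)F)cc3)c12`) gives 70700 nM and compound 2 (`O=c1oc2ccccc2c2nc3c(ccc4cc[nH]c43)c(-c3cccnc3Cl)c12`) gives 70700 nM, so compound 2 stands level with compound 1. Compound 3 (`O=c1oc2ccccc2c2nc3c(ccc4cc[nH]c43)c(-c3c(Cl)cccc3Cl)c12`) keeps the shared core and changes one group: 2,6-dichlorophenyl in place of 2-chloropyridin-3-yl on an aromatic carbon. The 2,6-dichlorophenyl enters on the same aromatic carbon, opposite the ring nitrogen. Going by the values given here, the only measured step at this carbon is no change at the digits printed from compound 1 to compound 2 (within the scatter), and it shows no size beyond the scatter. No step beyond the scatter is therefore expected in this assay. The expected step is a 1.0-fold lower number from compound 2 to compound 3 (0.00 log units; within the scatter). For compound 3 the estimated value is 70000 nM, with an expected range of 30000 nM to 120000 nM.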

Compound 3, half-maximal inhibitory concentration: 70700 nM
Beside the measured number, compound 3's estimate is 1.0-fold (0.00 log units) below it; low and high end bracket the measured number.
By their numbers in this assay, from the lowest: compounds 1, 2 and 3 (each within the scatter of the next).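

At the aromatic carbon opposite the ring nitrogen, this assay shows no change at the digits printed from compound 2 to compound 3 (within the scatter) and no change at the digits printed from compound 1 to compound 3 (within the scatter) on the shared core. A ring of carbon only with two chlorines, 2,6-dichlorophenyl, thus joins 2-chloropyridin-3-yl and 4-(trifluoromethyl)phenyl with no separation among the three aryl groups, which widens the flat reading that rested on a single step before. On these data alone, whether a non-aryl group on this carbon, such as an amine or a carboxylic acid, would move the number remains open. No data shown bear on why these three groups give matching numbers.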